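The compounds below may be only part of what the source reports. "The series", "measured", "known", "first", "only" and "open" are said of these compounds alone.

Measured so far in a functional assay on MCF7 cells (Homo sapiens) for cytotoxicity, read by MTT assay, with a stated time of 48 h, tested at 20 uM; on this read-out lower numbers stand for less inhibition and higher numbers for more inhibition at the one concentration tested (going by the name of the read-out):
compound 1 `CO[C@H]1O[C@H](COc2cccc3c2CCCC3)[C@@H](O)[C@H](O)[C@H]1Oc1ccc(OC2CCCCC2)cc1` — 3%
compound 2 `CO[C@H]1O[C@H](COc2ccc3c(c2)CCCC3)[C@@H](O)[C@H](O)[C@H]1Oc1ccc(OC2CCCCC2)cc1` — 45%
compound 3 `CO[C@@H]1O[C@H](COc2ccccc2)[C@@H](O)[C@H](O)[C@H]1Oc1ccc(OC2CCCCC2)cc1` — -5%

Compound 3 gives the lowest number of the three in this assay; against compound 1 it lies within the scatter, against compound 2 beyond it. For the measured compounds named here, the one measured step, a number 42 percentage points higher from compound 1 to compound 2 (beyond the scatter), concerns a change of attachment point on the tetrahydronaphthalenyl group and does not bear on a change of configuration. Compound 4 `CO[C@H]1O[C@H](COc2ccccc2)[C@@H](O)[C@H](O)[C@H]1Oc1ccc(OC2CCCCC2)cc1` differs from compound 3 only as follows: the two compounds have the same atoms and bonds and differ only in configuration as drawn: 1 of 5 stereo elements differ; a stereocentre at a saturated ring carbon is drawn R in compound 3 and S in compound 4. Going by the values given here, no measured pair tests such a change, so nothing beyond the scatter is expected from it; the estimated step is a number 8 percentage points higher from compound 3 to compound 4 (within the scatter). Compound 4 is therefore expected to give about 3% in this assay, between -12% and 18%.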

Compound 4, a percentage reported as inhibition, at one concentration (the size of the read-out at that concentration, not a potency): -9%
Compound 4: middle estimate off by 12 percentage points, on the high side; low and high end bracket the measured number.
By their numbers in this assay, from the lowest: compounds 4, 3 and 1 (each within the scatter of the next, the first and the last beyond it); then compound 2.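

In this assay the change of drawn configuration at this saturated ring carbon gives a number 4 percentage points lower from compound 3 to compound 4 (within the scatter) on a pair that isolates it: the fact that compounds 3 and 4 differ only in the configuration as drawn.
Set against phenyl, the 1,2,3,4-tetrahydronaphthalen-6-yl group gives the larger step, a number 54 percentage points lower from compound 2 to compound 4 (beyond the scatter), and the 1,2,3,4-tetrahydronaphthalen-5-yl group the smaller, a number 12 percentage points lower from compound 1 to compound 4 (beyond the scatter), so both attachment points now have a direct comparison with phenyl on that oxygen.

From the compounds shown here alone, whether the configuration at this carbon also matters with 1,2,3,4-tetrahydronaphthalen-6-yl in place of phenyl stays open. So does the effect of a phenyl carrying an amine or a carboxylic acid.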